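Series notes: compound 2 and its 3,5-dichlorophenyl analogue

This account rests on a few compounds, and the source may have more. Where it says the series, first, only, none or still open, it means among the compounds named here.

Measured so far:
compound 1, `O=C1COc2ccc(-c3[nH]c(-c4ccc(C(F)(F)F)cc4)nc3-c3ccccc3)cc2N1`: 103%
compound 2, `O=C1COc2ccc(-c3nn(-c4ccc(Br)cc4)cc3-c3ccccc3)cc2N1`: 81.5%

In a functional assay on A549 cells (Homo sapiens) for cytotoxicity, read by colorimetric assay and MTT assay, with a stated time of 3 days, tested at 1 uM (on this read-out higher numbers stand for a weaker effect at the one concentration tested and lower numbers for a stronger effect), compound 1 gives 103% and compound 2 gives 81.5%. Compound 2 stands lowest of the two numbers; its nearest neighbour is compound 1, whose number is higher by a margin beyond the usual scatter. Compound 3, `O=C1COc2ccc(-c3nn(-c4cc(Cl)cc(Cl)c4)cc3-c3ccccc3)cc2N1`, has not yet been measured. It differs from compound 2 in one place: 3,5-dichlorophenyl in place of 4-bromophenyl on an aromatic nitrogen. Among the compounds with values here, no step between two measured compounds shares this change, so nothing in the data gives the size of the step in this assay. The expectation is a step no larger than the scatter, with no set direction. Compound 3 is estimated at 80%, with a range from 62% to 98%. This estimate means an expected step of a number 1.5 percentage points lower from compound 2 to compound 3 (within the scatter), within the scatter.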

Compound 3, a percentage reported as activity, at one concentration (the size of the read-out at that concentration, not a potency): 93.1%
For compound 3 the middle estimate is 13.1 percentage points below the measured one; the range from low to high includes it.
By their numbers in this assay, from the lowest: compound 2; then compounds 3 and 1 (each within the scatter of the next).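

In this assay, the group on the aromatic nitrogen is shown to matter: 3,5-dichlorophenyl in place of 4-bromophenyl gives a number 11.6 percentage points higher from compound 2 to compound 3 (beyond the scatter), a modest step toward a weaker effect at the one concentration tested. The two groups match in their hydrogen-bond donor and acceptor counts and in net charge, so this position responds to a change that leaves those counts untouched. No measurement at hand accounts for the step.

With a single step at this position, the halogen and its place on the phenyl ring cannot be separated, since both change at once. From the compounds shown here alone, how this read-out would respond to an amine or a carboxylic acid on that phenyl ring, or to a longer alkyl chain on the same nitrogen, remains open.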